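A few compounds are considered here, and "the series" means these few. Any claim that something is new, unique, unknown or untested is made for them only; others in the source may bear on it.

Of the compounds shown here, three sharing one core have been measured in a functional assay on the whole organism (strain Kunming) with Mus musculus as the target, with a stated time of 0.5 h; a higher number here means that more compound is needed for the effect, a lower number that less compound is needed. Compound 1 `COc1cc(OC)c(OC)cc1/C=C/COC(=O)/C=C/c1c(OC)ccc(OC)c1OC` gives 53.5 mg/kg, compound 2 `COc1cc(OC)c(OC)cc1/C=C/COC(=O)/C=C/c1ccc(Br)cc1` gives 61.8 mg/kg, and compound 3 `COc1cc(OC)c(OC)cc1/C=C/COC(=O)/C=C/c1cccc(Br)c1` gives 75.7 mg/kg. Compound 2 thus lies within the scatter of both others, so these numbers show no clear spread.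

Compound 4 `COc1ccc(/C=C/C(=O)OC/C=C/c2cc(OC)c(OC)cc2OC)cc1` keeps the core of compound 2 and changes one group: methoxy in place of bromo on an aromatic carbon. In words, this is methoxy in place of bromo on an aromatic carbon, para to a large group.

Among the measured compounds shown here, no measured step makes this exact swap. For the measured compounds named here, the one measured step, 3-bromophenyl in place of 4-bromophenyl, gave a 1.2-fold higher number from compound 2 to compound 3 (0.09 log units; within the scatter). Compound 1, which has methoxy groups and no bromo on that aromatic ring, gives 53.5 mg/kg, within the scatter of compound 2. This is indirect evidence, but it points to no large shift.

The step expected in this assay is therefore none beyond the scatter, estimated as a 1.0-fold lower number from compound 2 to compound 4 (0.01 log units; within the scatter). For compound 4 the estimated value is 60 mg/kg, with an expected range of 35 mg/kg to 100 mg/kg.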

Compound 4, dose for half-maximal effect: 70.6 mg/kg
The estimate for compound 4 lay 1.2-fold (0.07 log units) below the measured number, and the stated range covers the measured number.
By their numbers in this assay, from the lowest: compounds 1, 2, 4 and 3 (each within the scatter of the next).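

In this assay, among the compounds shown here, methoxy in place of bromo on an aromatic carbon, para to a large group, gives a 1.1-fold higher number from compound 2 to compound 4 (0.06 log units; within the scatter) and so provides the direct reading of this swap that the earlier compounds could only hint at. The comparison with the other bromo compound gives a 1.1-fold lower number from compound 3 to compound 4 (0.03 log units; within the scatter) and likewise stays inside the usual spread, so 4-methoxyphenyl cannot be told apart from either 4-bromophenyl or 3-bromophenyl here. No measurement on hand offers an explanation for how close these numbers lie.

The compounds shown carry only bromo or methoxy groups on this ring, so it remains unknown how an amine, a carboxylic acid or a longer chain would behave there. From the compounds shown here alone, it also remains open whether any change on this ring can move the number beyond the scatter.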